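The source may report more compounds than this note shows. Statements on the series, on what has been measured and on what is new or still open speak of the compounds shown alone.

Values so far in a functional assay on HeLa cells (Homo sapiens) for cytotoxicity, read by MTT assay, with a stated time of 48 h; on this read-out higher numbers stand for weaker inhibition and lower numbers for stronger inhibition
Compound 1 `COc1cc(/C=C/C(=O)C2=C(/C=C/c3ccc(O)c(OC)c3)NC(=S)NC2c2ccccc2)ccc1O` gives 25000 nM
Compound 2 `COc1cc(/C=C/C(=O)C2=C(/C=C/c3ccc(O)c(OC)c3)NC(=S)NC2c2ccc(N(C)C)cc2)ccc1O` gives 12500 nM
Compound 3 `COc1cc(/C=C/C(=O)C2=C(/C=C/c3ccc(O)c(OC)c3)NC(=S)NC2c2c(Cl)cccc2Cl)ccc1O` has not been measured

In this assay compound 2 stands at 12500 nM, within the scatter of compound 1 at 25000 nM, so the two cannot be ranked. The change now followed is 2,6-dichlorophenyl in place of 4-(dimethylamino)phenyl on a saturated ring carbon. For the measured compounds named here, the only measured step bearing on it is a 2.0-fold lower number from compound 1 to compound 2 (0.30 log units; within the scatter), with dimethylamino in place of hydrogen on an aromatic carbon. Going by the values given here, no measured compound carries chlorine, so the effect of the entering group remains unknown. No step beyond the scatter is expected in this assay because a 2.0-fold lower number from compound 1 to compound 2 (0.30 log units; within the scatter) is the whole of the evidence. The expected change is a 1.2-fold higher number from compound 2 to compound 3 (0.08 log units; within the scatter), which is no real shift. In this assay compound 3 is estimated at 15000 nM, with an expected range from 6000 nM to 35000 nM.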

Compound 3, half-maximal inhibitory concentration: 100000 nM
Beside the measured number, compound 3's estimate is 6.7-fold (0.82 log units) below it; measured number outside the range, above it.
By their numbers in this assay, from the lowest: compounds 2 and 1 (each within the scatter of the next); then compound 3.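

In this assay, the substituent on this saturated ring carbon can move the read-out beyond the scatter, which the earlier pair of compounds did not show: 2,6-dichlorophenyl in place of 4-(dimethylamino)phenyl brings an 8.0-fold higher number from compound 2 to compound 3 (0.90 log units; beyond the scatter). The same group in place of phenyl brings a 4.0-fold higher number from compound 1 to compound 3 (0.60 log units; beyond the scatter), so the move to weaker inhibition holds against both of the other measured groups at this position. Nothing measured here accounts for this shift.

Still open, going by these compounds, is how a phenyl ring carrying a single chlorine would read at this position, which would help separate the presence of chlorine from the pattern of 2,6-dichlorophenyl. Also open, on these data alone, is how a methoxy group or a nitrile on the phenyl ring would compare with these three compounds.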